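A few compounds are considered here, and "the series" means these few. Any claim that something is new, unique, unknown or untested is made for them only; others in the source may bear on it.

Measured so far:
compound 1 `COc1cccc(CCCC(=O)Nc2nc3ccccc3c(=O)s2)c1`: 382 nM
compound 2 `COc1cccc(C#CC(=O)Nc2nc3ccccc3c(=O)s2)c1`: > 1000 nM

Going by the values given here, in an assay on CHO cells for displacement of a labelled ligand from adenosine receptor A3 (Homo sapiens), read by scintillation counting, with a stated time of 60 min (on this read-out lower numbers stand for stronger inhibition and higher numbers for weaker inhibition), compound 1 gives 382 nM, the only number obtained for a compound. Compound 2 returns only a limit in this assay, > 1000 nM, which is the limit of > 1000 nM in this assay, at which 1 of the 2 values shown sits, and not a measured number. Nothing therefore shows how strongly compound 2 itself binds. Among the compounds with values here, no pair of measured compounds that differ in one place exists, so no step has yet been measured.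

Compound 3 `O=C(CCCc1cccc(Cl)c1)Nc1nc2ccccc2c(=O)s1` has not been measured. It differs from compound 1 by chloro in place of methoxy on an aromatic carbon. Within the data shown here, with no measured step of the same kind, the change is expected to move the inhibition constant in this assay by little, in either direction or not beyond the usual scatter. Compound 3 is therefore expected to give 400 nM, most likely between 150 nM and 1100 nM. The step expected for it is a 1.0-fold higher number from compound 1 to compound 3 (0.02 log units; within the scatter).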

Compound 3, inhibition constant: > 1000 nM
Compound 3 gave a limit, no number (the forecaster's own chance of this, stated with the estimate: 20%); at least 2.5-fold (0.39 log units) between middle value and limit.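

Going by these compounds alone, replacing methoxy with chloro at this place on the aromatic ring gives the first single change that can be read in this assay, and the change is not neutral: it gives an at least 2.6-fold higher number from compound 1 to compound 3 (0.41 log units; beyond the scatter). This place on the ring therefore responds to the group it carries, at least for this pair, and chloro does not stand in for methoxy here. For compound 3, > 1000 nM is a limit and not a number, so the step gives only a smallest size, and most of the compounds shown now sit at that limit: the limit of > 1000 nM in this assay, at which 2 of the 3 values shown sit.

Going by these compounds, it remains open whether a hydroxyl, a methyl or an amine at this place would keep the binding seen with compound 1. One comparison also cannot show whether any other group here would do better than methoxy.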